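A sulfonamide-to-carboxamide swap at the solubility limit

The source may report more compounds than this note shows. Statements on the series, on what has been measured and on what is new or still open speak of the compounds shown alone.

Compound 2 `COc1ccc(-c2cc(-c3ccc(NS(C)(=O)=O)cc3)cnc2N)cn1` stands at the ceiling of a physicochemical assay for solubility, read by nephelometry, measured as kinetic solubility, at pH 2 (on this read-out higher numbers stand for higher solubility and lower numbers for lower solubility), where it gives > 100 ug/mL, a limit rather than a number. Compound 1 `COc1ccc(-c2cc(-c3ccc(S(=O)(=O)NC4CC4)cc3)cnc2N)cn1` likewise reaches only the limit, > 100 ug/mL, in this assay. Compound 3 `COc1ccc(-c2cc(-c3ccc4nccn4c3)cnc2N)cn1` also gives the limit > 100 ug/mL. Because of the limit of > 100 ug/mL in this assay, at which 3 of the 3 values shown sit, the step that the two limits leave unreadable from compound 1 to compound 2 cannot be sized. Compound 4 `COc1ccc(-c2cc(-c3ccc(C(N)=O)cc3)cnc2N)cn1` carries the change (carbamoyl in place of methanesulfonamido on an aromatic carbon), carbamoyl in place of methanesulfonamido on an aromatic carbon. Within the data shown here, no measured step in this assay can be read, so no shift beyond the scatter is expected for a step that the limit leaves unreadable from compound 2 to compound 4, and compound 4 is expected to sit at the limit as well. Compound 4 is therefore estimated at 150 ug/mL, with a range from 60 ug/mL to 400 ug/mL.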

Compound 4, solubility: > 100 ug/mL
Compound 4 gave a limit, no number; the forecaster's own chance of this, stated with the estimate: 80%; the middle value lies beyond the limit too.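

No new step can be read: the steps from compound 1 and from compound 2 to compound 4 stay unsized, because all the values share one limit: the limit of > 100 ug/mL in this assay, at which 4 of the 4 values shown sit. The compounds shown leave open whether compound 1, compound 2, compound 3 and compound 4 differ at all on this read-out.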